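The source may report more compounds than this note shows. Statements on the series, on what has been measured and on what is new or still open speak of the compounds shown alone.

In a functional assay on A549 cells (Homo sapiens) for antiproliferative activity, read by sulforhodamine B assay, with a stated time of 48 h (on this read-out lower numbers stand for stronger inhibition and higher numbers for weaker inhibition), compound 1, `COc1cc(C=C(C(=O)/C=C/c2cccc(OC)c2OC)C(=O)/C=C/c2cccc(OC)c2OC)cc(Br)c1O`, gives 200 nM. Compound 2, `COc1cc(C=C(C(=O)/C=C/c2cccc(OC)c2OC)C(=O)/C=C/c2cccc(OC)c2OC)cc(OC)c1O`, differs from it only by methoxy in place of bromo on an aromatic carbon; in this assay compound 2 gives 240 nM, and the step of a 1.2-fold higher number from compound 1 to compound 2 (0.08 log units; within the scatter) is small. Compound 3, `COc1cc(OC)c(/C=C/C(=O)C(=Cc2cc(Br)c(O)c(OC)c2)C(=O)/C=C/c2c(OC)cc(OC)cc2OC)c(OC)c1`, is built on a different core, and the difference between the two cores is not broken down here. In this assay compound 3 gives 730 nM, the highest of the three measured numbers. Compound 4, `COc1cc(OC)c(/C=C/C(=O)C(=Cc2cc(OC)c(O)c(OC)c2)C(=O)/C=C/c2c(OC)cc(OC)cc2OC)c(OC)c1`, has not yet been measured in this assay. It arises from compound 3 by methoxy in place of bromo on an aromatic carbon, the same change that separates compound 2 from compound 1, made at a place described in identical terms; among the compounds shown this change occurs twice. The earlier step of a 1.2-fold higher number from compound 1 to compound 2 (0.08 log units; within the scatter) is the basis for what is expected here. For compound 4 a step of similar size is expected, a 1.2-fold higher number from compound 3 to compound 4 (0.07 log units; within the scatter). Compound 4 is therefore estimated to give about 850 nM in this assay, with a likely range from 450 nM to 1600 nM.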

Compound 4, half-maximal inhibitory concentration: 340 nM
Beside the measured number, compound 4's estimate is 2.5-fold (0.40 log units) above it; the measured number lies below the stated range.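

In this assay, the change from 3-bromo-4-hydroxy-5-methoxyphenyl to 4-hydroxy-3,5-dimethoxyphenyl gives a 2.1-fold lower number from compound 3 to compound 4 (0.33 log units; beyond the scatter), a modest step. Set beside the earlier step on the core of compound 1, it cannot be told apart from that step, even though only the newer one lies beyond the scatter by itself: the same change on two cores in this assay, a 1.2-fold higher number (0.08 log units; within the scatter) from compound 1 to compound 2 and a 2.1-fold lower number (0.33 log units; beyond the scatter) from compound 3 to compound 4, 2.6-fold (0.41 log units) apart, within the scatter of two such steps This shows that the change can be carried between these two cores without a detectable difference in its effect, but two pairs do not prove that the effect is the same on both cores, do not establish a shared direction, and say nothing about why the numbers move.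

The compounds shown leave open how an amine, a carboxylic acid or a longer chain such as ethoxy would fare at this place on either core. They also leave open whether the step seen here would hold on a third core or in other cell lines.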